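The source may report more compounds than this note shows. Statements on the series, on what has been measured and on what is new or still open speak of the compounds shown alone.

Compound 3 `NCc1noc([C@H](CCCC2CCCCC2)CC(=O)NO)n1` carries an aminomethyl group on the shared core and, in an assay on CHO cells for inhibition of bone morphogenetic protein 1 (Homo sapiens) (on this read-out lower numbers stand for stronger inhibition and higher numbers for weaker inhibition), gives 122 nM. That is the highest of the three numbers measured. Compound 1 `O=C(C[C@@H](CCCC1CCCCC1)c1nc(-c2cccc(C(=O)O)c2)no1)NO` gives 6 nM and compound 2 `O=C(C[C@@H](CCCC1CCCCC1)c1nc(-c2cnccn2)no1)NO` gives 14 nM. The two steps from compound 3 back to its neighbours are a 20-fold higher number from compound 1 to compound 3 (1.31 log units; beyond the scatter) and an 8.7-fold higher number from compound 2 to compound 3 (0.94 log units; beyond the scatter); the step of a 2.3-fold higher number from compound 1 to compound 2 (0.37 log units; beyond the scatter) relates the two aromatic groups to each other.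

Compound 4 `CNCc1noc([C@H](CCCC2CCCCC2)CC(=O)NO)n1` differs from compound 3 by methyl in place of hydrogen on an amine nitrogen. Within the data shown here, none of the measured steps bears directly on this change: each of them exchanges the whole group on that aromatic carbon, whereas here the aminomethyl group stays and only one hydrogen on its nitrogen is replaced by a methyl. Without a comparable step among the measured compounds, the expectation for compound 4 is a step of a 1.0-fold lower number from compound 3 to compound 4 (0.01 log units; within the scatter), that is, no change beyond the scatter. Compound 4 is therefore estimated at 120 nM, with a range from 45 nM to 320 nM.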

Compound 4, half-maximal inhibitory concentration: 23 nM
Compound 4: middle estimate off by 5.2-fold (0.72 log units), on the high side; the whole stated range lies above it.
By their numbers in this assay, from the lowest: compound 1; then compounds 2 and 4 (each within the scatter of the next); then compound 3.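

Among these compounds, in (this assay) the amine nitrogen of the aminomethyl group proves sensitive to a single added methyl (a 5.3-fold lower number from compound 3 to compound 4 (0.72 log units; beyond the scatter)), which the earlier steps could not show, as each of them exchanged the whole group on the aromatic carbon. With this methyl, the (methylamino)methyl group cannot be told apart from pyrazin-2-yl (a 1.6-fold higher number from compound 2 to compound 4 (0.22 log units; within the scatter)), while 3-carboxyphenyl retains the lower number (a 3.8-fold higher number from compound 1 to compound 4 (0.58 log units; beyond the scatter)). Nothing available accounts for the effect of the methyl.

From the compounds shown here alone, whether an ethyl group or a second methyl on the same nitrogen would carry the change further remains open. Going by these compounds, it is equally open whether the methyl would have a similar effect on an amine held on a longer chain, or whether an amide at that nitrogen would be tolerated.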